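From a difluorophenyl amide to a cyclopropyl amide

The compounds below may be only part of what the source reports. "The series", "measured", "known", "first", "only" and "open" are said of these compounds alone.

Of the compounds shown here, three sharing one core have been measured in an assay on isolated protein for inhibition of sterol O-acyltransferase 1 (Mus musculus), tested at 0.1 uM; on this read-out lower numbers stand for less inhibition and higher numbers for more inhibition at the one concentration tested (going by the name of the read-out). Compound 1, `CCCCCCCCCCCCn1nnc(C(C(=O)Nc2ccc(F)cc2F)c2ccccc2)n1`, gives 1%, the lowest of the three numbers. Compound 2, `CCCCCCCCCCCCn1nnc(C(C(=O)Nc2c(OC)ncnc2OC)c2ccccc2)n1`, gives 39%, and compound 3, `CCCCCCCCCCCCn1nnc(C(C(=O)Nc2c(C)nn(C)c2C)c2ccccc2)n1`, gives 66%. The two measured steps away from compound 1 both run upward: a number 38 percentage points higher from compound 1 to compound 2 (beyond the scatter) and a number 65 percentage points higher from compound 1 to compound 3 (beyond the scatter), while a number 27 percentage points higher from compound 2 to compound 3 (beyond the scatter). So far, each replacement of the 2,4-difluorophenyl group on the amide-type nitrogen has raised inhibition.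

Compound 4, `CCCCCCCCCCCCn1nnc(C(C(=O)NC2CC2)c2ccccc2)n1`, is not yet measured. Compared with compound 1 the change is cyclopropyl in place of 2,4-difluorophenyl on an amide-type nitrogen. For the measured compounds named here, no measured step introduces a three-membered non-aromatic ring at this position; the steps from compound 1 to compounds 2 and 3 both swap one aromatic ring for another, so they bear on compound 4 only loosely, by showing that compound 1 has the lowest number of the three in this assay. Given that compound 1 sits at 1%, the expected step in this assay is a small rise, a number 14 percentage points higher from compound 1 to compound 4 (beyond the scatter), though a change within the scatter would not be surprising. Compound 4 is therefore estimated at 15%, with a range from 0% to 45%.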

Compound 4, a percentage reported as inhibition, at one concentration (the size of the read-out at that concentration, not a potency): 10%
Beside the measured number, compound 4's estimate is 5 percentage points above it; the measured number falls inside the stated range.
By their numbers in this assay, from the lowest: compounds 1 and 4 (each within the scatter of the next); then compound 2; then compound 3.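

Replacing the 2,4-difluorophenyl group on the amide-type nitrogen does not by itself raise inhibition: with cyclopropyl in its place, the step is a number 9 percentage points higher from compound 1 to compound 4 (within the scatter), so compound 4 goes against the rise seen with compound 2 and compound 3. Set against those two compounds, whose groups each hold an aromatic ring with hetero atoms, the small all-carbon ring falls well short, with steps of a number 56 percentage points lower from compound 3 to compound 4 (beyond the scatter) and a number 29 percentage points lower from compound 2 to compound 4 (beyond the scatter), so the higher numbers at this position go with those particular groups and not with just any replacement. Nothing available here explains these differences.

The compounds shown leave open whether the higher numbers depend on having an aromatic ring at this position, on the hetero atoms within it, or on the groups attached to it, since these features change together from one compound to the next. A plain phenyl, a cyclohexyl ring, or the 1,3,5-trimethyl-1H-pyrazol-4-yl ring stripped of its methyl groups would each test one of these features more directly than the present compounds can.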